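Changing the hydroxyphenyl group on the shared core

The compounds below may be only part of what the source reports. "The series", "measured", "known", "first", "only" and "open" are said of these compounds alone.

Measured compounds:
- compound 1 `O=C1N=C(N2N=C(c3ccccc3)CC2c2ccccc2O)S/C1=C1/C(=O)Nc2ccccc21`: 2040 nM
- compound 2 `O=C1N=C(N2N=C(c3ccccc3)CC2c2ccccc2O)S/C1=C1/C(=O)Nc2ccc(Br)cc21`: 230 nM
- compound 3 `COc1ccc(C2=NN(C3=NC(=O)/C(=C4\C(=O)Nc5ccc(Cl)cc54)S3)C(c3ccc(OC)cc3)C2)cc1`: 190 nM

In a functional assay on cells (Melanoma cell, Homo sapiens) for cytotoxicity, read by sulforhodamine B assay, with a stated time of 48 h (on this read-out lower numbers stand for stronger inhibition of growth and higher numbers for weaker inhibition of growth), compound 1 gives the highest of the three numbers, so it is the weakest of the measured set. Among the measured compounds shown here, the only single-point step measured, an 8.9-fold lower number from compound 1 to compound 2 (0.95 log units; beyond the scatter), concerns a change on a different part of the core. For the measured compounds named here, no single step connects compound 1 to compound 3, which differs from it in several places at once; compound 3 gives 190 nM.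

Compound 4 `O=C1N=C(N2N=C(c3ccccc3)CC2c2ccc(Cl)cc2)S/C1=C1/C(=O)Nc2ccccc21` is still to be measured. It differs from compound 1 by 4-chlorophenyl in place of 2-hydroxyphenyl on a saturated ring carbon. Going by the values given here, no measured step touches this saturated ring carbon, so the measured data give no direction for this change; the expected step of a 1.4-fold lower number from compound 1 to compound 4 (0.13 log units; within the scatter) is therefore an estimate of little or no movement beyond the scatter, with a wide range. Compound 4 is expected to give about 1500 nM in this assay, between 400 nM and 6000 nM.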

Compound 4, concentration for 50% growth inhibition: 280 nM
Compound 4: the middle estimate sits 5.4-fold (0.73 log units) above what was measured; measured number outside the range, below it.
By their numbers in this assay, from the lowest: compounds 3, 2 and 4 (each within the scatter of the next); then compound 1.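

In this assay, the saturated ring carbon turns out to be a position that matters: the first measured change there, a 7.3-fold lower number from compound 1 to compound 4 (0.86 log units; beyond the scatter), lies beyond the scatter. The step removes the hydrogen-bond donor and acceptor counted on 2-hydroxyphenyl, so on this core neither is needed for a number in this lower range. No measurement available gives a reason for the drop.

The swap changes both the substituent and its place on the phenyl ring, so the compounds shown leave open which of the two matters. Also open, on these data alone, is whether a plain phenyl, or a phenyl carrying an amine or a carboxylic acid, would behave like 4-chlorophenyl, and whether this change would add to the bromo change elsewhere on the core.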